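Swapping the triazole amine for a chloropyrimidine amine

A few compounds are considered here, and "the series" means these few. Any claim that something is new, unique, unknown or untested is made for them only; others in the source may bear on it.

Measured so far:
- compound 1, `CCO/C(O)=C1\C(COCCNc2n[nH]c(N)n2)=NC(C)=C(C(=O)OC)C1c1cccc(Cl)c1`: 126 nM
- compound 2, `CCO/C(O)=C1\C(COCCNc2nc(N)n(C)n2)=NC(C)=C(C(=O)OC)C1c1cccc(Cl)c1Cl`: 3.98 nM
- compound 3, `CCO/C(O)=C1\C(COCCNc2nc(O)cc(-c3ccccc3)n2)=NC(C)=C(C(=O)OC)C1c1cccc(Cl)c1Cl`: 7.94 nM

These three compounds share one core and differ in the heteroaromatic group carried on the amine nitrogen of the side chain, and in the chlorine pattern on the phenyl ring. In a functional assay (aorta) with Rattus norvegicus as the target (a lower number here means a stronger inhibitor, a higher number a weaker inhibitor), compound 2 gives the lowest number of the three. Compound 3 stands closest to it, and the gap between them lies within the scatter, so nothing separates the two. Compound 1 stands far off, with a gap well beyond the scatter.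

Compound 4, `CCO/C(O)=C1\C(COCCNc2cc(Cl)ncn2)=NC(C)=C(C(=O)OC)C1c1cccc(Cl)c1Cl`, has not yet been measured. It differs from compound 2 in one place: 6-chloropyrimidin-4-yl in place of 5-amino-1-methyl-1H-1,2,4-triazol-3-yl on an amine nitrogen. Going by the values given here, no measured pair follows exactly this exchange, so the step has to be judged from what the three measured compounds show. Compound 2 and compound 3 carry quite different heteroaromatic groups on that nitrogen and still give numbers within the scatter of each other, which suggests that this position tolerates change. For compound 4 a small weakening is therefore expected in this assay, a step of a 2.0-fold higher number from compound 2 to compound 4 (0.30 log units; within the scatter), close to the scatter. The estimate for compound 4 is 8 nM, with a range from 2 nM to 32 nM.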

Compound 4, half-maximal inhibitory concentration: 12.6 nM
Estimate against measurement, compound 4: 1.6-fold (0.20 log units) below, and the stated range covers the measured number.
By their numbers in this assay, from the lowest: compounds 2, 3 and 4 (each within the scatter of the next, the first and the last beyond it); then compound 1.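

Going by these compounds alone, compound 2 and compound 4 give the first exchange at this amine nitrogen that can be read on its own, since they differ in nothing else. In this assay the exchange gives a 3.2-fold higher number from compound 2 to compound 4 (0.50 log units; beyond the scatter) and so has a measurable but modest cost: the position accepts a very different ring, but it is not entirely indifferent to the group it carries. The step also comes with several changes at once, as the same heavy-atom count hides a five-membered ring giving way to a six-membered one, a chlorine entering, and hydrogen-bond donors falling from 1 to 0, and nothing available here shows which of these differences accounts for the step.

A pyrimidin-4-yl group with an amino group or a plain hydrogen in place of the chlorine would help separate the effect of the chlorine from that of the ring. Going by these compounds, it also remains open whether the same exchange would give a step of similar size on a core with a single chlorine on the phenyl ring, as in compound 1.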